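This account rests on a few compounds, and the source may have more. Where it says the series, first, only, none or still open, it means among the compounds named here.

In a functional assay on A-431 cells (Homo sapiens) for antiproliferative activity, read by sulforhodamine B assay, with a stated time of 72 h (a lower number here means a stronger inhibitor, a higher number a weaker inhibitor), compound 1 `C=C1CC(CBr)(c2ccccc2)OC1=O` gives 1480 nM. Compound 2 `C=C1C[C@](CBr)(c2ccccc2)OC1=O`, with the same atoms and bonds but a defined configuration at its stereocentre, gives 1330 nM, and compound 3 `C=C1CC(CBr)(c2ccc(C)cc2)OC1=O`, with methyl in place of hydrogen on an aromatic carbon, gives 2200 nM. Compound 1 therefore stands close to both: its nearest step is a 1.1-fold lower number from compound 1 to compound 2 (0.05 log units; within the scatter) and its furthest is a 1.5-fold higher number from compound 1 to compound 3 (0.17 log units; within the scatter), both within the scatter.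

Compound 4 `C=C1CC(CBr)(c2ccccc2OC)OC1=O` makes a single change to compound 1: methoxy in place of hydrogen on an aromatic carbon. The stereo step concerns a different part of the molecule, so it offers little guidance here. Among the compounds with values here, the methyl step is the closest precedent, since it also replaces a hydrogen on an aromatic carbon, although no measured compound carries methoxy. Going by compound 3 and a 1.5-fold higher number from compound 1 to compound 3 (0.17 log units; within the scatter), a slightly higher number but no change beyond the scatter is expected in this assay. The expected move is a 1.4-fold higher number from compound 1 to compound 4 (0.13 log units; within the scatter). For compound 4, the estimated value is 2000 nM, within an expected range from 900 nM to 4500 nM.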

Compound 4, half-maximal inhibitory concentration: 2400 nM
Compound 4: the middle estimate sits 1.2-fold (0.08 log units) below what was measured; low and high end bracket the measured number.
By their numbers in this assay, from the lowest: compounds 2, 1, 3 and 4 (each within the scatter of the next).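

In this assay, methoxy on an aromatic carbon, ortho to a group of 9 heavy atoms, gives a 1.6-fold higher number from compound 1 to compound 4 (0.21 log units; within the scatter). Within the data shown here, this position on the aromatic ring can therefore carry a group of carbon and oxygen without a step beyond the scatter, whereas the earlier compounds showed such a step only for methyl in place of hydrogen on an aromatic carbon. Among these compounds, the only structural information available concerns the drawn configuration in compound 2, and it says nothing about why this ring change gives the number it does.

Going by these compounds, whether an amine, a carboxylic acid or a longer chain such as butoxy at this position would stay within the scatter of compound 1 remains open. The compounds shown also leave open whether methoxy on another aromatic carbon of the ring would give a similar number.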